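The source may report more compounds than this note shows. Statements on the series, on what has been measured and on what is new or still open speak of the compounds shown alone.

Compound 1 `CC(C)c1onc(-c2c(Cl)cccc2Cl)c1COc1ccc(N(C)Cc2ccc(OCC(=O)O)cc2)c(C(F)(F)F)n1`: 90%
Compound 2 `CN(Cc1cccc(C(=O)O)c1)c1ccc(OCc2c(-c3c(Cl)cccc3Cl)noc2C2CC2)nc1C(F)(F)F`: 102%
Compound 3 `CC(C)c1onc(-c2c(Cl)cccc2Cl)c1COc1ccc(N(C)Cc2cccc(C(=O)NS(C)(=O)=O)c2)c(C(F)(F)F)n1`: 110%

These three compounds were measured in an assay on isolated protein for agonist activity at Bile acid receptor (Homo sapiens), read by FRET; a higher number here means a larger maximal response, a lower number a smaller maximal response. Compound 2 stands second highest of the three: its value lies within the usual scatter of that of compound 3, while compound 1 sits beyond the scatter below it. Compound 4 `CC(Oc1cccc(C(=O)O)c1)c1ccc(OCc2c(-c3c(Cl)cccc3Cl)noc2C2CC2)nc1C(F)(F)F` has not yet been measured in this assay. It differs from compound 2 in one place: 1-(3-carboxyphenoxy)ethyl in place of (3-carboxybenzyl)(methyl)amino on an aromatic carbon. Going by the values given here, no step between two measured compounds is known, so the effect of this change can only be guessed. Because compound 2 gives 102% in this assay and the other two measured values sit close to it near a full response, the step of a number 2 percentage points lower from compound 2 to compound 4 (within the scatter) is expected to be small, probably within the scatter, with no clear direction. Compound 4 is expected to give 100%, in the range 75% to 120%.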

Compound 4, largest response reached (reported as efficacy), in percent of the reference or control that the assay uses: 102%
Beside the measured number, compound 4's estimate is 2 percentage points below it; the range from low to high includes it.
By their numbers in this assay, from the lowest: compound 1; then compounds 2, 4 and 3 (each within the scatter of the next).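

In this assay, going by these compounds alone, placing 1-(3-carboxyphenoxy)ethyl in place of (3-carboxybenzyl)(methyl)amino gives no change at the digits printed from compound 2 to compound 4 (within the scatter) and is the first step read at this position, ortho to a trifluoromethyl group. The link carrying the carboxyphenyl part can therefore hold oxygen and a branched carbon instead of the methylated amine nitrogen, with the maximal response staying within the scatter. Nothing available explains this outcome. From the compounds shown here alone, whether a tetrazole in place of the carboxylic acid, or a longer chain at this position, would also preserve the response remains open.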